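The source may hold more compounds than are shown below. What is called first, only, known or untested is meant among the compounds shown, and "the series" means these compounds.

In an ADME assay on Vero cells (Chlorocebus sabaeus) for cytotoxicity, read by MTT assay, with a stated time of 72 h (a higher number here means that more compound is tolerated, a lower number that less compound is tolerated), compound 1 `C[C@]1(CN2CCc3nc(-c4ccccc4)ccc3C2)Cn2cc([N+](=O)[O-])nc2O1` gives > 32 ug/mL, which is a limit of the assay and not a number. Compound 2 `C[C@]1(CN2CCc3nc(-c4cc(F)ccc4Cl)ccc3C2)Cn2cc([N+](=O)[O-])nc2O1` gives > 32 ug/mL, again a limit. Compound 3 `C[C@]1(CN2CCc3nc(-c4cccc(Cl)c4F)ccc3C2)Cn2cc([N+](=O)[O-])nc2O1` gives > 32 ug/mL, also a limit. It therefore stands level with the rest of the set: the limit of > 32 ug/mL in this assay, at which 3 of the 3 values shown sit.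

Compound 4 `C[C@]1(CN2CCc3nc(-c4ccc(Cl)c(F)c4)ccc3C2)Cn2cc([N+](=O)[O-])nc2O1` differs from compound 3 only in the aryl group: 4-chloro-3-fluorophenyl in place of 3-chloro-2-fluorophenyl on an aromatic carbon. The same atoms are joined differently, with 4-chloro-3-fluorophenyl in place of 3-chloro-2-fluorophenyl on an aromatic carbon.

Three measured swaps at this aryl group bear on the change: a step that the two limits leave unreadable from compound 1 to compound 2, a step that the two limits leave unreadable from compound 1 to compound 3 and a step that the two limits leave unreadable from compound 2 to compound 3. None has a readable size, so the series gives no measured effect of moving the halogens. For the measured compounds named here, all three aryl groups tested so far do stay at the limit, and no compound goes against that.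

Resting on a step that the two limits leave unreadable from compound 2 to compound 3, the swap between two chlorofluorophenyl groups, no step beyond the scatter is expected in this assay, in either direction. The estimated change is a step that the limit leaves unreadable from compound 3 to compound 4. For compound 4 the estimate is 40 ug/mL, with an expected range of 20 ug/mL to 80 ug/mL, and a result reported again only as a limit is the likeliest outcome.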

Compound 4, half-maximal cytotoxic concentration: > 32 ug/mL
Compound 4 ended at the assay's limit; the forecaster's own chance of this, stated with the estimate: 85%; the middle value lies beyond the limit too.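

In this assay compound 4 gives > 32 ug/mL, a limit of the assay and not a number. Its steps from compound 1, compound 2 and compound 3 therefore cannot be read, and the series stays level: the limit of > 32 ug/mL in this assay, at which 4 of the 4 values shown sit. The compounds shown leave open whether these aryl groups differ at all in this assay.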